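This account rests on a few compounds, and the source may have more. Where it says the series, first, only, none or still open, it means among the compounds named here.

Measured compounds in a functional assay on DU-145 cells (Homo sapiens) for inhibition, read by trypan blue exclusion, with a stated time of 96 h; a higher number here means a weaker inhibitor of growth, a lower number a stronger inhibitor of growth:
Compound 1, `Cc1ccc(CS(=O)(=O)/C(=C/c2ccc(Br)cc2)C(=O)c2ccc(Cl)cc2)cc1`, gives 25000 nM.
Compound 2, `CSc1ccc(/C=C(/SCc2ccc(Br)cc2)C(=O)c2ccc(C(=O)O)cc2)cc1`, gives 10000 nM.
Compound 3, `O=C(/C(=C\c1cc(Br)c(O)c(Br)c1)SCc1ccc(Br)cc1)c1ccc(Br)cc1`, gives 1000 nM.

Among these three, compound 1 has the highest number in this assay and is therefore the weakest inhibitor of growth; compound 2 stands nearest to it and compound 3 furthest, and both gaps lie beyond the scatter. Going by the values given here, no pair of the measured compounds differs in only one place, so no single step between them can be read off.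

Compound 4, `Cc1ccc(CS(=O)(=O)/C(=C/c2c[nH]c3ccc(Br)cc23)C(=O)c2ccc(Cl)cc2)cc1`, has not yet been measured in this assay. It differs from compound 1 in this way: 5-bromo-1H-indol-3-yl in place of 4-bromophenyl on a double-bonded chain carbon bound to a double-bonded chain carbon. Among the compounds with values here, with no comparable step among the measured compounds, the expectation rests on compound 1 alone, whose value in this assay of 25000 nM leaves ample room for a lower number. The step expected is a 3.1-fold lower number from compound 1 to compound 4 (0.49 log units; beyond the scatter), a moderate fall that would lie beyond the scatter. Compound 4 is estimated at 8000 nM in this assay, with a range from 2000 nM to 30000 nM.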

Compound 4, concentration for 50% growth inhibition: 10000 nM
Compound 4: the middle estimate sits 1.3-fold (0.10 log units) below what was measured; low and high end bracket the measured number.
By their numbers in this assay, from the lowest: compound 3; then compounds 2 and 4 (each within the scatter of the next); then compound 1.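

Going by these compounds alone, this is the first single change that can be read in this assay: with 5-bromo-1H-indol-3-yl in place of 4-bromophenyl on a double-bonded chain carbon bound to a double-bonded chain carbon, the result is a 2.5-fold lower number from compound 1 to compound 4 (0.40 log units; beyond the scatter) as a modest gain. It shows that this position tolerates the larger two-ring group, which brings a hydrogen-bond donor, without loss of growth inhibition. No evidence is available to account for the size of this step. The compounds shown leave open whether the same exchange would give a similar step in the other measured compounds, which carry a sulfur link without the two oxygens of compound 1. They also leave open what an amine or a nitrile in place of the bromine of 5-bromo-1H-indol-3-yl would give.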